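A few compounds are considered here, and "the series" means these few. Any claim that something is new, unique, unknown or untested is made for them only; others in the source may bear on it.

The measured compounds:

Compound 1, `Cc1ncc([N+](=O)[O-])n1CCSc1nnc(-c2ccc([N+](=O)[O-])cc2)o1`, gives 12700 nM in a functional assay on MCF7 cells (Homo sapiens) for cytotoxicity, read by MTT assay, with a stated time of 48 h; a higher number here means a weaker inhibitor, a lower number a stronger inhibitor.
Compound 2, `Cc1ncc([N+](=O)[O-])n1CCSc1nnc(-c2ccc(F)cc2)o1`, gives 8100 nM.
Compound 3, `Cc1ncc([N+](=O)[O-])n1CCSc1nnc(-c2ccc(N(C)C)cc2)o1`, gives 14900 nM.

All three share one core and differ only in the group on the outer benzene ring. Compound 2 has the lowest of the three numbers, but its neighbours sit close: the step of a 1.6-fold lower number from compound 1 to compound 2 (0.20 log units; within the scatter) and the step of a 1.8-fold higher number from compound 2 to compound 3 (0.26 log units; within the scatter) both fall within the scatter, as does a 1.2-fold higher number from compound 1 to compound 3 (0.07 log units; within the scatter). So far, then, nothing on the outer ring has moved the number in a way one can trust.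

Compound 4, `Cc1ncc([N+](=O)[O-])n1CCSc1nnc(-c2cccnc2)o1`, carries a different change: pyridin-3-yl in place of 4-fluorophenyl on an aromatic carbon. Among the measured compounds shown here, this is a swap of the whole ring rather than a group on it, so none of the measured steps copies it; they only show that the outer ring has so far tolerated varied groups without a clear shift. The expectation is therefore a step of about a 1.2-fold higher number from compound 2 to compound 4 (0.07 log units; within the scatter), not beyond the scatter. Compound 4 is estimated at 9500 nM, with a range of 4000 nM to 22000 nM.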

Compound 4, half-maximal inhibitory concentration: 28700 nM
The estimate for compound 4 lay 3.0-fold (0.48 log units) below the measured number; measured number above the stated range.
By their numbers in this assay, from the lowest: compounds 2, 1, 3 and 4 (each within the scatter of the next, the first and the last beyond it).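

In this assay, among the compounds shown here, the ring swap gives a 3.5-fold higher number from compound 2 to compound 4 (0.55 log units; beyond the scatter) and is the first step to pass the scatter, though only modestly. This place on the core therefore does not accept every change without a shift in the number, yet compound 4 stays within the scatter of compound 3, so the swap clearly separates it only from compound 2. No measurement here explains the shift.

The swap removes the fluorine and brings in a ring nitrogen at once, so the compounds shown cannot say which of the two matters. A plain phenyl group would separate these two changes, and pyridin-4-yl would show whether the place of the ring nitrogen matters.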